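Working notes: from compound 2 to compound 4

A few compounds are considered here, and "the series" means these few. Any claim that something is new, unique, unknown or untested is made for them only; others in the source may bear on it.

- compound 1 `COc1ccc(C(=O)CCN2CCN(c3ccc(C(F)(F)F)cc3)CC2)cc1OC`: 243000 nM
- compound 2 `O=C(CCN1CCN(c2ccc(C(F)(F)F)cc2)CC1)c1ccc(Br)cc1`: 78800 nM
- compound 3 `O=C(CCN1CCN(c2ccc(Cl)cc2)CC1)c1ccc(Br)cc1`: 52100 nM

All three values come from an ADME assay on Vero cells (Chlorocebus sabaeus) for cytotoxicity, read by resazurin assay, with a stated time of 72 h; on this read-out lower numbers stand for stronger inhibition and higher numbers for weaker inhibition. Compound 2 lies within the scatter of compound 3, and its number is lower than that of compound 1 by a margin beyond the scatter.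

The next compound is compound 4 `O=C(CCN1CCN(c2ccc(C(F)(F)F)cc2)CC1)c1ccc(F)c(Cl)c1`, with 3-chloro-4-fluorophenyl in place of 4-bromophenyl on a carbonyl carbon.

Within the data shown here, only one measured step falls at this place: a 3.1-fold lower number from compound 1 to compound 2 (0.49 log units; beyond the scatter). It is modest, and it replaces 3,4-dimethoxyphenyl rather than exchanging one halogen-bearing phenyl for another. The other measured step, a 1.5-fold lower number from compound 2 to compound 3 (0.18 log units; within the scatter), is chloro in place of trifluoromethyl on an aromatic carbon, a different change that stays within the scatter. Among the measured compounds shown here, no measured pair matches the new change directly.

No step beyond the scatter is therefore expected in this assay, and no direction is favoured with any confidence. The expectation starts from compound 2 at 78800 nM. The estimated step is a 1.1-fold lower number from compound 2 to compound 4 (0.05 log units; within the scatter). Compound 4 is estimated at 70000 nM, with an expected range of 33000 nM to 150000 nM.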

Compound 4, half-maximal inhibitory concentration: 74500 nM
For compound 4 the middle estimate is 1.1-fold (0.03 log units) below the measured one, within the range that was stated.
By their numbers in this assay, from the lowest: compounds 3, 4 and 2 (each within the scatter of the next); then compound 1.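

In this assay the place on the carbonyl carbon now carries two different halogen-bearing phenyl groups, and 3-chloro-4-fluorophenyl in place of 4-bromophenyl gives a 1.1-fold lower number from compound 2 to compound 4 (0.02 log units; within the scatter) and so no readable difference between them. Among these compounds, the 3-chloro-4-fluorophenyl group also gives a 3.3-fold lower number from compound 1 to compound 4 (0.51 log units; beyond the scatter) when it takes the place of 3,4-dimethoxyphenyl, a gap of similar size to a 3.1-fold lower number from compound 1 to compound 2 (0.49 log units; beyond the scatter) and one that shows the separation from compound 1 is not confined to 4-bromophenyl, with no compound at this place going against it. Nothing available bears on the reason for either step.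

Open, as far as these compounds go, is whether a phenyl with no halogen, or one carrying a single methoxy group, an amine or a carboxylic acid, would fall with compounds 2 and 4 or with compound 1. Also open, from the compounds shown here alone, is whether chloro in place of trifluoromethyl on the aromatic carbon, which stayed within the scatter with 4-bromophenyl, would behave the same way with 3-chloro-4-fluorophenyl on the carbonyl carbon.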